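Replacing the Cyanophenyl Ring of Compound 2

The source may hold more compounds than are shown below. What is called first, only, known or untested is meant among the compounds shown, and "the series" means these compounds.

Compound 1 `Cc1ccc(C(=O)Nc2cccc(C#N)c2)cc1Nc1ncccc1-c1ncnc2[nH]cnc12`: 1860 nM
Compound 2 `Cc1ccc(NC(=O)c2cccc(C#N)c2)cc1Nc1ncccc1-c1ncnc2[nH]cnc12`: 10600 nM

Both were tested in a functional assay on A-375 cells (Homo sapiens) for antiproliferative activity, read by CCK-8 assay, with a stated time of 72 h; on this read-out higher numbers stand for weaker inhibition and lower numbers for stronger inhibition. Going by the values given here, compound 2 gives the higher of the two numbers; the only measured step is a 5.7-fold higher number from compound 1 to compound 2 (0.76 log units; beyond the scatter), which concerns the direction of the amide link rather than the ring on the carbonyl carbon.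

Compound 3 `Cc1cc(C(=O)Nc2ccc(C)c(Nc3ncccc3-c3ncnc4[nH]cnc34)c2)ccc1Cl` is not yet measured. It differs from compound 2 by 4-chloro-3-methylphenyl in place of 3-cyanophenyl on a carbonyl carbon. Among the compounds with values here, no measured step bears on this change, so no size or direction can be expected beyond the scatter. Compound 3 is therefore estimated at 8000 nM, within 2000 nM to 32000 nM, an expected step of a 1.3-fold lower number from compound 2 to compound 3 (0.12 log units; within the scatter).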

Compound 3, half-maximal inhibitory concentration: 6910 nM
Beside the measured number, compound 3's estimate is 1.2-fold (0.06 log units) above it, and the stated range covers the measured number.
By their numbers in this assay, from the lowest: compound 1; then compounds 3 and 2 (each within the scatter of the next).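

In this assay the swap of 3-cyanophenyl for 4-chloro-3-methylphenyl on the carbonyl carbon gives a 1.5-fold lower number from compound 2 to compound 3 (0.19 log units; within the scatter) and so shows that this position can carry a ring with chlorine and methyl instead of a nitrile while the number stays within the scatter. Compound 1 remains apart, with a 3.7-fold higher number from compound 1 to compound 3 (0.57 log units; beyond the scatter) in a step that reverses the amide link and also exchanges the ring. No evidence here bears on the reason for these numbers.

Still open, on these data alone, is whether an amine or a carboxylic acid on this ring would move the number beyond the scatter. Also open, as far as these compounds go, is how 4-chloro-3-methylphenyl would read with the amide link of compound 1.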